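The compounds below may be only part of what the source reports. "The series", "measured", "known", "first", "only" and "open" are said of these compounds alone.

Measured compounds:
compound 1 `O=c1c2c(C(F)(F)F)cc(-c3ccccc3)nc2ncn1Cc1cn(CCC(F)(F)C(F)(F)C(F)(F)C(F)(F)C(F)(F)C(F)(F)C(F)(F)C(F)(F)F)nn1`. In a functional assay on THP-1 cells (Homo sapiens) for cytotoxicity, read by MTT assay, with a stated time of 24 h (a higher number here means a weaker inhibitor, a lower number a stronger inhibitor), compound 1 gives 79.1 ug/mL.
compound 2 `CCc1nc2nc(-c3ccccc3)cc(C(F)(F)F)c2c(=O)n1Cc1cn(CCC(F)(F)C(F)(F)C(F)(F)C(F)(F)C(F)(F)C(F)(F)C(F)(F)C(F)(F)F)nn1`. In this assay compound 2 gives only a limit, > 200 ug/mL.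
compound 3 `CCCCCCc1nc2nc(-c3ccccc3)cc(C(F)(F)F)c2c(=O)n1Cc1cn(CCC(F)(F)C(F)(F)C(F)(F)C(F)(F)C(F)(F)C(F)(F)F)nn1`. In this assay compound 3 gives only a limit, > 200 ug/mL.

Compound 3 stands at the limit of this assay, with no number behind it; the same holds for compound 2, see (the limit of > 200 ug/mL in this assay, at which 2 of the 3 values shown sit). For the measured compounds named here, the one measured step, an at least 2.5-fold higher number from compound 1 to compound 2 (0.40 log units; beyond the scatter), runs from a number up to the limit and concerns the ethyl on an aromatic carbon, not the fluorinated chain.

Compound 4 `CCCCCCc1nc2nc(-c3ccccc3)cc(C(F)(F)F)c2c(=O)n1Cc1cn(CCC(F)(F)C(F)(F)C(F)(F)C(F)(F)C(F)(F)C(F)(F)C(F)(F)C(F)(F)F)nn1` differs from compound 3 by 1,1,2,2,2-pentafluoroethyl in place of fluoro on a saturated chain carbon bound to two fluorine atoms and a saturated chain carbon. Going by the values given here, no measured step bears on this change: compound 1 and compound 2 carry the longer chain of compound 4, compound 3 the shorter one, and no pair of measured compounds differs in the chain alone. With compound 3 already at the limit and the chain change uncharted, the expected step is a step that the limit leaves unreadable from compound 3 to compound 4, none beyond the scatter. For compound 4 the estimate is 250 ug/mL, between 120 ug/mL and 600 ug/mL, and most likely reported again as a limit rather than a number.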

Compound 4, half-maximal inhibitory concentration: > 200 ug/mL
Compound 4 ended at the assay's limit; the forecaster's own chance of this, stated with the estimate: 75%; the middle value does not contradict the limit.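

A hexyl group on the aromatic carbon gives an at least 2.5-fold higher number from compound 1 to compound 4 (0.40 log units; beyond the scatter) in this assay, so a second alkyl group at this place now separates from compound 1, as ethyl did. On these data alone, as both steps end at a limit, they fix only a lower bound, and the true size of each remains unknown. The other new steps cannot be read, so 1,1,2,2,2-pentafluoroethyl in place of fluoro on the chain has no measurable size here, and compound 1 remains the only compound with a number: the limit of > 200 ug/mL in this assay, at which 3 of the 4 values shown sit.

As far as these compounds go, whether the fluorinated chain changes the reading at all stays open, since it could only show against a compound that gives a number in this assay, such as compound 1. Also open, from the compounds shown here alone, is what a methyl or an amine on that aromatic carbon would give.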